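The source may report more compounds than this note shows. Statements on the series, on what has been measured and on what is new or still open speak of the compounds shown alone.

Values in an assay on mitochondria from L6 cells (Rattus norvegicus) for activation, with a stated time of 90 min; on this read-out higher numbers stand for an effect only at larger amounts of compound and lower numbers for an effect already at smaller amounts:
compound 1 `Fc1ccccc1Nc1nc2nonc2nc1Nc1ccccc1`: 2200 nM
compound 2 `Fc1ccccc1Nc1nc2nonc2nc1Nc1cccc(F)c1F`: 500 nM
compound 3 `Fc1ccc(Nc2nc3nonc3nc2Nc2ccccc2F)c(F)c1`: 300 nM

Compound 1 stands highest of the three numbers; the nearest is a 4.4-fold lower number from compound 1 to compound 2 (0.64 log units; beyond the scatter) and the furthest a 7.3-fold lower number from compound 1 to compound 3 (0.87 log units; beyond the scatter). Compound 4 `O=C(Nc1ccc(Nc2nc3nonc3nc2Nc2ccccc2F)cc1)C(F)(F)F` differs from compound 1 by ((trifluoromethyl)carbonyl)amino in place of hydrogen on an aromatic carbon. The measured steps concern fluorine on that same ring, not an amide, so none bears directly on this change; they only show that substitution on that ring gave modest reductions in the number, and compound 2 to compound 3 stays within the scatter. For compound 4 a small downward step or none beyond the scatter is therefore expected, written as a 1.6-fold lower number from compound 1 to compound 4 (0.20 log units; within the scatter). Compound 4 is estimated at 1400 nM, in the range 400 nM to 5000 nM.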

Compound 4, half-maximal effective concentration: 4100 nM
Compound 4: middle estimate off by 2.9-fold (0.47 log units), on the low side; the measured number falls inside the stated range.
By their numbers in this assay, from the lowest: compounds 3 and 2 (each within the scatter of the next); then compounds 1 and 4 (each within the scatter of the next).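

In this assay, ((trifluoromethyl)carbonyl)amino on an aromatic carbon para to a large group gives a 1.9-fold higher number from compound 1 to compound 4 (0.27 log units; within the scatter), so this substituent of 7 heavy atoms is accommodated without a change beyond the scatter. Fluorine substitution on this ring had given a 7.3-fold lower number from compound 1 to compound 3 (0.87 log units; beyond the scatter), and the amide does not repeat that drop. No measured evidence accounts for this difference.

On these data alone, whether an amine, a carboxylic acid or a longer chain in place of trifluoromethyl would also stay level with compound 1 remains open.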